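The source may report more compounds than this note shows. Statements on the series, on what has been measured and on what is new or still open speak of the compounds shown alone.

In a toxicity assay on Vero cells (Chlorocebus sabaeus) for cytotoxicity, read by MTT assay (a higher number here means a weaker inhibitor, a lower number a stronger inhibitor), compound 1 `COC(=O)NC(=O)c1ccsc1NC(=O)c1ccc(S(=O)(=O)N2CCC2)cc1` gives 17.5 ug/mL. Compound 2 `CCOC(=O)NC(=O)c1ccsc1NC(=O)c1ccc(S(=O)(=O)N2CCC2)cc1` gives > 64 ug/mL, which is a limit of the assay and not a number. Compound 2 therefore stands at the limit of > 64 ug/mL in this assay, at which 1 of the 2 values shown sits.

Compound 3 `CCOC(=O)NC(=O)c1ccsc1NC(=O)c1ccc(S(=O)(=O)N2CCC(OC)CC2)cc1` keeps the rest of compound 2 and has 4-methoxypiperidin-1-yl in place of azetidin-1-yl on a sulfonyl sulfur. Among the measured compounds shown here, the one measured step, an at least 3.6-fold higher number from compound 1 to compound 2 (0.56 log units; beyond the scatter), lies beyond the scatter, but it left the azetidin-1-yl in place, so it gives no direct size for this change. For the measured compounds named here, no measured step touches that group, so only a small change of no firm direction can be expected, staying within the scatter. The estimated step is an at least 1.1-fold lower number from compound 2 to compound 3 (0.06 log units; that floor lies within the scatter). The expected value for compound 3 is 55 ug/mL, with an estimated range from 18 ug/mL to 128 ug/mL.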

Compound 3, half-maximal inhibitory concentration: 21 ug/mL
For compound 3 the middle estimate is 2.6-fold (0.42 log units) above the measured one, within the range that was stated.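

Among the compounds shown here, this is the first sign that the group on the sulfonyl sulfur moves the number in this assay: putting 4-methoxypiperidin-1-yl in place of azetidin-1-yl gives an at least 3.0-fold lower number from compound 2 to compound 3 (0.48 log units; beyond the scatter). The earlier step, an at least 3.6-fold higher number from compound 1 to compound 2 (0.56 log units; beyond the scatter), therefore no longer stands alone, since a change on the sulfonyl sulfur also shifts this read-out, here towards stronger inhibition of the cells. Compound 2 carries a limit and not a number, so the true size of the new step may exceed this floor: the limit of > 64 ug/mL in this assay, at which 1 of the 3 values shown sits.

As far as these compounds go, the change swaps the ring size and adds the methoxy group at once, so the share of each remains open, and plain piperidin-1-yl or morpholin-4-yl on the sulfonyl sulfur would help to separate them. From the compounds shown here alone, whether the same swap acts alike on compound 1 also remains open.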